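This account rests on a few compounds, and the source may have more. Where it says the series, first, only, none or still open, it means among the compounds named here.

Series notes. Compound 1 `CCC(CC)Nc1nc(OC)c(-c2ccc(Cl)cc2Cl)nc1C` is measured in an in vitro ADME assay on microsomes (Rattus norvegicus) for metabolic stability (a lower number here means that the compound disappears faster, a higher number that the compound lasts longer), where compound 1 gives 0.283 h. Compound 2 `CCc1nc(-c2ccc(Cl)cc2Cl)c(CC)nc1NC(CC)CC` gives 0.07 h in this assay, and compound 3 `CCc1nc(NC(CC)CC)c(F)nc1-c1ccc(Cl)cc1Cl` gives 0.35 h. Compound 1 stands second highest of the three numbers: the gap to compound 3 is within the scatter, so no order between compound 1 and compound 3 is claimed, while compound 2 sits lower by a gap beyond the scatter. Among the measured compounds shown here, the only single-change step in the set, a 5.0-fold higher number from compound 2 to compound 3 (0.70 log units; beyond the scatter), concerns a different change from the one taken here and bears on it only loosely, as an example of what one substituent swap on the shared core can do.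

Compound 4 `CCC(CC)Nc1nc(OC)c(-c2ccc(Cl)cc2Cl)nc1OC` differs from compound 1 by methoxy in place of methyl on an aromatic carbon. For the measured compounds named here, no measured step concerns methoxy in place of methyl, so the series gives no direction, and the step expected in this assay from compound 1 to compound 4 is one within the scatter. Compound 4 is accordingly estimated at 0.32 h, with a range from 0.14 h to 0.75 h. As a step this estimate means a 1.1-fold higher number from compound 1 to compound 4 (0.05 log units; within the scatter) is expected.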

Compound 4, half-life: 0.0417 h
Estimate against measurement, compound 4: 7.7-fold (0.89 log units) above; the whole stated range lies above it.
By their numbers in this assay, from the lowest: compounds 4 and 2 (each within the scatter of the next); then compounds 1 and 3 (each within the scatter of the next).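

Methoxy in place of methyl on this aromatic carbon, next to the ring nitrogen and ortho to a (pentan-3-yl)amino group, is not a neutral swap in this assay (a 6.8-fold lower number from compound 1 to compound 4 (0.83 log units; beyond the scatter)). Among the compounds shown here, this is the first reading of this change, and it shows that a single added oxygen-linked carbon at this place can shift the number beyond the scatter, here downward, whereas the only earlier step, fluoro in place of ethyl, went upward (a 5.0-fold higher number from compound 2 to compound 3 (0.70 log units; beyond the scatter)). Nothing available gives a reason for the fall.

Open, on these data alone, is whether the lower number belongs to methoxy alone or would also come with a hydroxyl, an amine or a chloro group at this place. Also open, as far as these compounds go, is whether the swap reads the same when the para methoxy group is replaced by another group.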